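Cytotoxicity of a nitrogen-substituent series on the shared core

This account rests on a few compounds, and the source may have more. Where it says the series, first, only, none or still open, it means among the compounds named here.

Of the compounds shown here, three sharing one core have been measured in an ADME assay on MT4 cells (Homo sapiens) for cytotoxicity, read by MTT assay, with a stated time of 5 days; a lower number here means that less compound is tolerated, a higher number that more compound is tolerated. Compound 1 `CC(C)CN(c1ccnc(Nc2ccc(C#N)cc2)n1)c1c(F)cc(-c2ccc(C#N)cc2)cc1F` gives 241000 nM. Compound 2 `CCC(C)N(c1ccnc(Nc2ccc(C#N)cc2)n1)c1c(F)cc(-c2ccc(C#N)cc2)cc1F` gives 217000 nM. Compound 3 `N#Cc1ccc(Nc2nccc(N(c3c(F)cc(-c4ccc(C#N)cc4)cc3F)C3CCCC3)n2)cc1` gives 232000 nM. Compound 3 thus sits among three numbers that are all within the scatter of one another: the step of a 1.0-fold lower number from compound 1 to compound 3 (0.02 log units; within the scatter) and the step of a 1.1-fold higher number from compound 2 to compound 3 (0.03 log units; within the scatter) are both small, as is the step of a 1.1-fold lower number from compound 1 to compound 2 (0.05 log units; within the scatter).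

Compound 4 `N#Cc1ccc(Nc2nccc(N(CCCCl)c3c(F)cc(-c4ccc(C#N)cc4)cc3F)n2)cc1` has not yet been measured in this assay. It differs from compound 3 in one place: 3-chloropropyl in place of cyclopentyl on a nitrogen on an aromatic ring. The measured steps that bear on this change are the exchanges of one saturated group for another on the same nitrogen, and none of them moved the number beyond the scatter. For the measured compounds named here, none of them, however, brings a chlorine or an open chain in place of the ring, so there is no direct precedent for this change. The expectation for compound 4 is therefore a step of a 1.1-fold lower number from compound 3 to compound 4 (0.02 log units; within the scatter), that is, no change beyond the scatter. Compound 4 is estimated to give 220000 nM in this assay, within a range from 110000 nM to 440000 nM.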

Compound 4, half-maximal cytotoxic concentration: > 250000 nM
Compound 4 gave a limit, no number; the forecaster's own chance of this, stated with the estimate: 15%; middle value at least 1.1-fold (0.05 log units) away from the limit.
By their numbers in this assay, from the lowest: compounds 2, 3 and 1 (each within the scatter of the next). At a limit, above all of these: compound 4.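

In this assay compound 4 gives a limit and not a number: the limit of > 250000 nM in this assay, at which 1 of the 4 values shown sits.

Read against the other compounds, the result can only be given as floors, namely an at least 1.0-fold higher number from compound 3 to compound 4 (0.03 log units; that floor lies within the scatter) and an at least 1.1-fold higher number from compound 2 to compound 4 (0.06 log units; that floor lies within the scatter) and an at least 1.0-fold higher number from compound 1 to compound 4 (0.01 log units; that floor lies within the scatter). Going by these compounds, how far compound 4 truly stands from the others therefore stays unknown, yet none of these steps points to a lower number. The earlier compounds shown here showed only exchanges among saturated carbon groups on this nitrogen, whereas compound 4 adds a further kind of change: the five-membered ring of compound 3 leaves, an open 3-chloropropyl chain carrying a chlorine enters, and the read-out shows no fall in the concentration tolerated.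

On these data alone, whether a true number for compound 4 would lie beyond the scatter of compounds 1, 2 and 3 remains open. The compounds shown also leave open whether the same picture holds when the chain ends in an amine or a carboxylic acid in place of the chlorine, or when a longer chain stands on this nitrogen.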